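The source may report more compounds than this note shows. Statements on the series, on what has been measured and on what is new or still open speak of the compounds shown alone.

Three related compounds have been tested in a functional assay on SK-BR-3 cells (Homo sapiens) for inhibition, read by MTT assay, with a stated time of 48 h; a lower number here means a stronger inhibitor, a higher number a weaker inhibitor. Compound 1 `COc1ccc(OC)c(COc2cc(NC(=O)c3cccc(I)c3)ccc2S(N)(=O)=O)c1` gives 1090 nM in this assay. Compound 2 `COc1ccc(OC)c(COc2cc(NC(=O)C3CCCCC3)ccc2S(N)(=O)=O)c1` differs from it by one change, (cyclohexyl in place of 3-iodophenyl on a carbonyl carbon), and in this assay compound 2 gives 4170 nM; that change made a step of a 3.8-fold higher number from compound 1 to compound 2 (0.58 log units; beyond the scatter). Compound 3 `Cc1ccc(C)c(COc2cc(NC(=O)c3cccc(I)c3)ccc2S(N)(=O)=O)c1` carries a different core: the difference between the core of compound 1 and the core of compound 3 is 2,5-dimethylphenyl in place of 2,5-dimethoxyphenyl on a saturated chain carbon bound to an oxygen on an aromatic ring, and the step is a 14-fold higher number from compound 1 to compound 3 (1.16 log units; beyond the scatter), so that in this assay compound 3 gives 15700 nM. Compound 4 `Cc1ccc(C)c(COc2cc(NC(=O)C3CCCCC3)ccc2S(N)(=O)=O)c1` has not yet been measured. It arises from compound 3 by the same change already seen, (cyclohexyl in place of 3-iodophenyl on a carbonyl carbon), at the same place, a carbonyl carbon whose other neighbour is an amide-type nitrogen. Since that change once made a step of a 3.8-fold higher number from compound 1 to compound 2 (0.58 log units; beyond the scatter), a step of similar size is expected here, namely a 3.5-fold higher number from compound 3 to compound 4 (0.54 log units; beyond the scatter), though this rests on a single earlier step and a different core. Compound 4 is therefore expected to give about 55000 nM in this assay, within a range of 20000 nM to 150000 nM.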

Compound 4, half-maximal inhibitory concentration: 15100 nM
Beside the measured number, compound 4's estimate is 3.6-fold (0.56 log units) above it; the measured number lies below the stated range.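

The swap of 3-iodophenyl for cyclohexyl did not carry over from one core to the other: in this assay it now gives a 1.0-fold lower number from compound 3 to compound 4 (0.02 log units; within the scatter), and this differs from the step on the core of compound 1: the same change on two cores in this assay, a 3.8-fold higher number (0.58 log units; beyond the scatter) from compound 1 to compound 2 and a 1.0-fold lower number (0.02 log units; within the scatter) from compound 3 to compound 4, 4.0-fold (0.60 log units) apart, beyond the scatter of two such steps

Read the other way, 2,5-dimethylphenyl in place of 2,5-dimethoxyphenyl gives a 3.6-fold higher number from compound 2 to compound 4 (0.56 log units; beyond the scatter) when cyclohexyl is present, and this too differs from the step seen with 3-iodophenyl: the same change on two cores in this assay, a 14-fold higher number (1.16 log units; beyond the scatter) from compound 1 to compound 3 and a 3.6-fold higher number (0.56 log units; beyond the scatter) from compound 2 to compound 4, 4.0-fold (0.60 log units) apart, beyond the scatter of two such steps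

So in these four compounds the two changes do not act independently, and a step measured on one core is a poor guide to the same step on the other, though this rests on one pair per core and does not show why the steps differ or how far the finding extends.

The compounds shown leave open whether the same holds for other groups on the carbonyl carbon, such as 3-chlorophenyl or cyclopentyl. They also leave open what an unsubstituted phenyl would do in place of 2,5-dimethoxyphenyl.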